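A Third Aryl Group on the Shared Core

The source may hold more compounds than are shown below. What is called first, only, known or untested is meant among the compounds shown, and "the series" means these compounds.

In a functional assay on HepG2 cells (Homo sapiens) for antiproliferative activity, read by sulforhodamine B assay, with a stated time of 48 h (a lower number here means a stronger inhibitor, a higher number a weaker inhibitor), compound 1 `COc1ccc(C=C(C(=O)/C=C/c2cccc(OC)c2OC)C(=O)/C=C/c2cccc(OC)c2OC)cc1OC` reads 200 nM and compound 2 `COc1cccc(/C=C/C(=O)C(=Cc2ccc(O)c(F)c2)C(=O)/C=C/c2cccc(OC)c2OC)c1OC` reads 220 nM on the same scale. These two values lie within the scatter of each other, so compound 2 stands level with compound 1. Among the measured compounds shown here, compound 3 `COc1cc(C=C(C(=O)/C=C/c2cccc(OC)c2OC)C(=O)/C=C/c2cccc(OC)c2OC)cc(OC)c1O` differs from compound 2 by 4-hydroxy-3,5-dimethoxyphenyl in place of 3-fluoro-4-hydroxyphenyl on a double-bonded chain carbon bound to a double-bonded chain carbon as its single change. For the measured compounds named here, the only guide is a 1.1-fold higher number from compound 1 to compound 2 (0.04 log units; within the scatter) at this same place, so no step beyond the scatter is expected in this assay here. The estimated step of a 1.1-fold lower number from compound 2 to compound 3 (0.04 log units; within the scatter) is accordingly small. Compound 3 is estimated at 200 nM with an expected range of 80 nM to 500 nM as its reading.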

Compound 3, half-maximal inhibitory concentration: 210 nM
For compound 3 the middle estimate is 1.1-fold (0.02 log units) below the measured one, and the stated range covers the measured number.
By their numbers in this assay, from the lowest: compounds 1, 3 and 2 (each within the scatter of the next).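

In this assay the step of a 1.0-fold lower number from compound 2 to compound 3 (0.02 log units; within the scatter) and the step of a 1.1-fold higher number from compound 1 to compound 3 (0.02 log units; within the scatter) both stay within the scatter when 4-hydroxy-3,5-dimethoxyphenyl takes this place on the shared core. Three different aryl groups now read level here, including one with more heavy atoms and more hydrogen-bond acceptors than 3-fluoro-4-hydroxyphenyl. Nothing at hand explains why these readings stay level.

The compounds shown leave open whether an aryl group carrying an amine or a carboxylic acid would also read level at this place. They also leave open how a longer alkyl chain would read in place of the aryl group.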